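Swapping Chloro for Methoxy in a Growth Inhibition Series

A few compounds are considered here, and "the series" means these few. Any claim that something is new, unique, unknown or untested is made for them only; others in the source may bear on it.

Of the compounds shown here, three sharing one core have been tested in a functional assay on OVCAR-3 cells (Homo sapiens) for inhibition, read by sulforhodamine B assay, with a stated time of 48 h; on this read-out higher numbers stand for weaker inhibition of growth and lower numbers for stronger inhibition of growth. Compound 1 `N=C(N)c1ccc(-c2ccc(-c3cc(Cl)cc(Cl)c3)s2)cc1` gives 1700 nM. Compound 3 `COc1cc(OC)cc(-c2ccc(-c3ccc(C(=N)N)c(F)c3)s2)c1` gives 815 nM. Compound 2 `N=C(N)c1ccc(-c2ccc(-c3ccc(Cl)cc3)s2)cc1F` gives 268 nM, the lowest of the three numbers, beyond the scatter from both others, with the smaller gap to compound 3 and the larger gap to compound 1. The next compound, compound 4 `COc1ccc(-c2ccc(-c3ccc(C(=N)N)c(F)c3)s2)cc1`, differs from compound 2 in one place: methoxy in place of chloro on an aromatic carbon. No measured pair isolates this change, so the size of the step cannot be read from the data shown. A modest weakening, only just beyond the scatter, is expected, a 2.1-fold higher number from compound 2 to compound 4 (0.31 log units; beyond the scatter). Compound 4 is therefore estimated at 550 nM, within a range from 180 nM to 1700 nM.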

Compound 4, concentration for 50% growth inhibition: 9770 nM
The estimate for compound 4 lay 18-fold (1.25 log units) below the measured number; the whole stated range lies below it.
By their numbers in this assay, from the lowest: compound 2; then compound 3; then compound 1; then compound 4.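

In this assay this position proves highly sensitive: with methoxy in place of chloro on the six-membered aromatic ring, para to a large group, the change is large (a 36-fold higher number from compound 2 to compound 4 (1.56 log units; beyond the scatter)). The single added heavy atom and hydrogen-bond acceptor are thus accompanied by much weaker growth inhibition, though this rests on one pair. Nothing measured here bears on the reason for the loss. Open, on these data alone, is whether methyl, hydroxyl or an amine at this place would be tolerated, and whether the same swap costs as much on other versions of the shared core.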